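Swapping methyl for fluoro on the triazole aryl ring

The source may report more compounds than this note shows. Statements on the series, on what has been measured and on what is new or still open speak of the compounds shown alone.

Compound 1 `C=C1C[C@]23C[C@@]1(O)CC[C@@H]2c1cccc(C)c1[C@@H]3Cn1cc(-c2ccc(C)cc2)nn1` was tested in a functional assay on SMMC-7721 cells (Homo sapiens) for cytotoxicity, read by MTT assay, with a stated time of 4 days; a higher number here means a weaker inhibitor, a lower number a stronger inhibitor. In this assay compound 1 gives only a limit, > 20000 nM, not a measured number. Compound 2 `C=C1C[C@]23C[C@@]1(O)CC[C@H]2c1ccc(OS(=O)(=O)c2ccc(C)cc2)c(C)c1[C@@H]3Cn1cc(-c2ccc(OC)cc2)nn1` likewise gives only a limit, > 20000 nM. Compound 3 `C=C1C[C@]23C[C@@]1(O)CC[C@H]2c1ccc(OS(=O)(=O)c2ccc(C)cc2)c(C)c1[C@@H]3Cn1cc(-c2ccc(C)cc2)nn1` also returns only a limit, > 20000 nM. The step from compound 2 to compound 3 a step that the two limits leave unreadable from compound 2 to compound 3 is therefore unreadable, and the limit of > 20000 nM in this assay, at which 3 of the 3 values shown sit, shows all values sitting at the same limit. The new compound 4 `C=C1C[C@]23C[C@@]1(O)CC[C@@H]2c1cccc(C)c1[C@@H]3Cn1cc(-c2ccc(F)cc2)nn1` differs from compound 1 by fluoro in place of methyl on an aromatic carbon. Among the compounds with values here, no measured step covers this change, and every value so far is a limit, so no shift beyond the scatter can be expected from a step that the limit leaves unreadable from compound 1 to compound 4; compound 4 is estimated at 30000 nM, within 10000 nM to 100000 nM.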

Compound 4, half-maximal inhibitory concentration: > 20000 nM
Compound 4 ended at the assay's limit (the forecaster's own chance of this, stated with the estimate: 85%); the middle value is on the limit's open side.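

Compound 1 and compound 4 both return only a limit, so no step can be read for the change from 4-methylphenyl to 4-fluorophenyl: the limit of > 20000 nM in this assay, at which 4 of the 4 values shown sit.

The compounds shown leave open which change, if any, would give a measured number in this assay rather than a limit.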